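Opening the imidazolidinone ring of compound 3

The source may hold more compounds than are shown below. What is called first, only, known or untested is meant among the compounds shown, and "the series" means these compounds.

Compound 1 `COc1cc(NC(C)CCCN2C(=O)[C@H](C)NC2(C)C)c2ncccc2c1`: 71000 nM
Compound 2 `COc1cc(NC(C)CCCN2C(=O)CN(C(=O)[C@H](C)N)C2(C)C)c2ncccc2c1`: > 100000 nM
Compound 3 `COc1cc(NC(C)CCCNC(=O)CN2C(=O)[C@H](C)NC2(C)C)c2ncccc2c1`: 58000 nM

Of the compounds shown here, three sharing the same core have been measured in a functional assay on Caco-2 cells (Homo sapiens) for antiproliferative activity, read by sulforhodamine B assay, with a stated time of 48 h; on this read-out lower numbers stand for stronger inhibition and higher numbers for weaker inhibition. Compound 1 gives 71000 nM. For compound 2 the assay reports only a limit, > 100000 nM. Compound 3 gives 58000 nM, the lower of the two numbers shown, though its gap to compound 1 lies within the usual scatter, so no order between the two can be read.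

Compound 4 `COc1cc(NC(C)CCCNC(=O)CNC(=O)[C@H](C)N)c2ncccc2c1` has not yet been measured. It differs from compound 3 by ((1-aminoethyl)carbonyl)amino in place of 2,2,4-trimethyl-5-oxoimidazolidin-1-yl on a saturated chain carbon bound to a carbonyl carbon; in words, ((1-aminoethyl)carbonyl)amino in place of 2,2,4-trimethyl-5-oxoimidazolidin-1-yl on a saturated chain carbon bound to a carbonyl carbon. Within the data shown here, no step between measured compounds tells what this change does, and all three measured values sit at weak inhibition, so the step from compound 3 to compound 4 in this assay is expected to be small, with a modest shift towards a higher number: a 1.3-fold higher number from compound 3 to compound 4 (0.11 log units; within the scatter). Compound 4 is therefore estimated at 75000 nM, within a range of 25000 nM to 200000 nM.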

Compound 4, half-maximal inhibitory concentration: > 100000 nM
Compound 4 was reported as a limit; the forecaster's own chance of this, stated with the estimate: 35%; at least 1.3-fold (0.12 log units) between middle value and limit.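

In this assay, putting ((1-aminoethyl)carbonyl)amino in place of 2,2,4-trimethyl-5-oxoimidazolidin-1-yl on a saturated chain carbon bound to a carbonyl carbon gives an at least 1.7-fold higher number from compound 3 to compound 4 (0.23 log units; that floor lies within the scatter). From the compounds shown here alone, compound 4 is reported only as a limit, > 100000 nM, so the step is a floor whose full size stays unknown, and since that floor lies within the scatter, it does not by itself establish a loss of inhibition. What the open form does show is that this change brings no measurable gain at this position, and the step ends at a limit that is now shared: the limit of > 100000 nM in this assay, at which 2 of the 4 values shown sit.

The compounds shown leave open whether the ring itself matters or only the groups it carries. They also leave open whether a hydroxyl in place of the terminal amine, or a longer chain at this position, would bring a number below the limit.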